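Methoxy to hydroxy: what to expect for compound 3

The source may report more compounds than this note shows. Statements on the series, on what has been measured and on what is new or still open speak of the compounds shown alone.

- Compound 1 `CCCCc1ccc2[nH]c(-c3ccc(OC)cc3)c(/C=N/NC(=O)c3ccccc3)c2c1` gives 32 nM
- Compound 2 `CCCCc1ccc2[nH]c(-c3ccc(OC)cc3)c(/C=N/NC(=O)c3cccc(OC)c3)c2c1` gives 55 nM

Both numbers come from a functional assay on MDA-MB-231 cells (Homo sapiens) for antiproliferative activity, with a stated time of 4 days; a lower number here means a stronger inhibitor, a higher number a weaker inhibitor. Only these two compounds have been measured, and compound 2 lies within the usual scatter of compound 1, so the pair cannot be ranked.

The next compound is compound 3 `CCCCc1ccc2[nH]c(-c3ccc(OC)cc3)c(/C=N/NC(=O)c3cccc(O)c3)c2c1`, which has not yet been measured. It carries hydrogen in place of methyl on an oxygen on an aromatic ring, turning the 3-methoxyphenyl of compound 2 into 3-hydroxyphenyl (hydrogen in place of methyl on an oxygen on an aromatic ring).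

Within the data shown here, only one measured step bears on this change: a 1.7-fold higher number from compound 1 to compound 2 (0.24 log units; within the scatter). That step installs the same methoxy in place of hydrogen, and its size stays within the scatter. Among the measured compounds shown here, it gives a weak guide at best, since no compound with a hydroxy group has been measured. No step beyond the scatter is therefore expected, and no direction can be favoured.

The expected step in this assay is a 1.1-fold higher number from compound 2 to compound 3 (0.04 log units; within the scatter), and it is only an estimate. Compound 3 is estimated at 60 nM (expected range 20 nM to 180 nM).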

Compound 3, half-maximal inhibitory concentration: 30 nM
Beside the measured number, compound 3's estimate is 2.0-fold (0.30 log units) above it; low and high end bracket the measured number.
By their numbers in this assay, from the lowest: compounds 3, 1 and 2 (each within the scatter of the next).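

In this assay, going from methoxy to hydroxy on the aromatic ring gives a 1.8-fold lower number from compound 2 to compound 3 (0.26 log units; within the scatter), so the methyl on that oxygen can be removed without the number moving beyond what repeat measurements would show, and this step cannot be read as a real gain. Compared with the compound that carries only hydrogen at this place, putting a hydroxy group there gives a 1.1-fold lower number from compound 1 to compound 3 (0.03 log units; within the scatter), which makes hydroxy the second group after methoxy to leave the number within the scatter of compound 1. Hydrogen, methoxy and hydroxy therefore cannot be told apart at this position in this assay, and nothing measured here says why the three numbers lie so close together.

As far as these compounds go, whether this tolerance extends to quite different groups at the same place, such as an amine or a carboxylic acid, or to a longer chain on the oxygen, such as ethoxy, remains open. From the compounds shown here alone, it is also open whether hydroxy would behave the same way elsewhere on this ring, since all three compounds differ at this one place only.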